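Chloro in place of methyl: working notes on the series

The source may hold more compounds than are shown below. What is called first, only, known or untested is meant among the compounds shown, and "the series" means these compounds.

Of the compounds shown here, two have been measured so far in a functional assay on P388 cells (Mus musculus) for antiproliferative activity; on this read-out lower numbers stand for stronger inhibition and higher numbers for weaker inhibition. Compound 1 (`COc1ccc(S(=O)(=O)Nc2cccc3cc[nH]c23)cc1`) gives 1.1 ug/mL in this read-out. Compound 2 (`Cc1ccc(S(=O)(=O)Nc2cccc3cc[nH]c23)cc1`) gives 4.3 ug/mL as the higher and therefore weaker of the two numbers.

The next compound is compound 3 (`O=S(=O)(Nc1cccc2cc[nH]c12)c1ccc(Cl)cc1`), which carries chloro in place of methyl on an aromatic carbon, para to a large group (chloro in place of methyl on an aromatic carbon).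

For the measured compounds named here, the one measured step that bears on this change is a 3.9-fold higher number from compound 1 to compound 2 (0.59 log units; beyond the scatter) and it lies beyond the scatter while remaining modest. Going by the values given here, that step involves the same methyl group, but no chloro compound has been measured yet. It therefore sets a rough scale for a single-group replacement and gives no firm direction for this one. Only a small change in this assay is expected, most likely within the scatter. The estimated change is a 1.4-fold lower number from compound 2 to compound 3 (0.16 log units; within the scatter) and this lean towards a lower number is tentative. For compound 3 the expected value is 3 ug/mL (estimated range 1 ug/mL to 9 ug/mL).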

Compound 3, half-maximal inhibitory concentration: 6 ug/mL
Beside the measured number, compound 3's estimate is 2.0-fold (0.30 log units) below it; low and high end bracket the measured number.
By their numbers in this assay, from the lowest: compound 1; then compounds 2 and 3 (each within the scatter of the next).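

Notes on the chloro result in this assay: at this place, on an aromatic carbon para to a large group, chloro in place of methyl gives a step within the scatter (a 1.4-fold higher number from compound 2 to compound 3 (0.14 log units; within the scatter)), so these two groups cannot be told apart on this read-out. Methoxy now stands apart from two groups rather than one, since chloro in place of methoxy (a 5.5-fold higher number from compound 1 to compound 3 (0.74 log units; beyond the scatter)) lies beyond the scatter, as does methyl in place of methoxy (a 3.9-fold higher number from compound 1 to compound 2 (0.59 log units; beyond the scatter)), and compound 1 alone has the lower number. Nothing at hand accounts for the separation of methoxy from methyl and chloro.

Still open, going by these compounds, is whether the lower number of compound 1 is particular to methoxy or is shared by other groups on the same carbon, such as a hydroxyl, an amine, or a longer chain like ethoxy. The compounds shown also leave open how a carboxylic acid or a nitrile at this place would compare with methoxy on this read-out.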